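The source may hold more compounds than are shown below. What is called first, only, known or untested is meant among the compounds shown, and "the series" means these compounds.

Working notes on the series. In a functional assay on MCF7 cells (Homo sapiens) for inhibition, read by MTT assay, with a stated time of 72 h (a lower number here means a stronger inhibitor, a higher number a weaker inhibitor), compound 1 `Nc1nc2cc(-c3nn(CCCC(=O)NO)c4ncnc(N)c34)ccc2o1` gives > 50000 nM. This is a limit of the assay and not a number, so the position of compound 1 is bounded on one side only. The record so far reads: the limit of > 50000 nM in this assay, at which 1 of the 2 values shown sits. For the measured compounds named here, compound 2 `Nc1ncnc2c1c(-c1cnc3[nH]ccc3c1)nn2CCCCCCC(=O)NO` gives 19800 nM in this assay, the only actual number to date.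

Compound 3 `CNC(=O)CCCCCCCn1nc(-c2ccc3oc(N)nc3c2)c2c(N)ncnc21` has not yet been measured. Its difference from compound 1 is 4-(methylcarbamoyl)butyl in place of hydroxycarbamoyl on a saturated chain carbon, three bonds along the chain from an aromatic nitrogen. In words, 4-(methylcarbamoyl)butyl stands in place of hydroxycarbamoyl on a saturated chain carbon, three bonds along the chain from an aromatic nitrogen.

Going by the values given here, no measured step in this assay covers this change, so the expectation has only weak support. The expected step, a number no higher from compound 1 to compound 3 (the limit leaves the size open), is none beyond the scatter in either direction, and another report of only a limit is more likely than not. For compound 3 the estimate is 50000 nM, with an expected range of 20000 nM to 100000 nM.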

Compound 3, half-maximal inhibitory concentration: 7220 nM
Estimate against measurement, compound 3: 6.9-fold (0.84 log units) above, and the stated range ends above it.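

In this assay, replacing hydroxycarbamoyl with 4-(methylcarbamoyl)butyl on a saturated chain carbon, three bonds along the chain from an aromatic nitrogen, gives an at least 6.9-fold lower number from compound 1 to compound 3 (0.84 log units; beyond the scatter). For the compounds shown here, this is the first measured step, and it shows that hydroxycarbamoyl is not needed at this position for a measured number on the core of compound 1, since compound 3 gives 7220 nM without it. The value for compound 1 is a limit of the assay, so the step has a lower bound but no upper bound: the limit of > 50000 nM in this assay, at which 1 of the 3 values shown sits.

The change swaps the end group and lengthens the chain in one step, so the compounds shown cannot separate the contribution of the methylcarbamoyl end from that of the added chain carbons. Going by these compounds, a carboxylic acid or a primary amide at the end of the same chain, or hydroxycarbamoyl on a longer chain on this core, would pull those two apart, and it remains open whether the step carries over to a core other than that of compound 1.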